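Benzoyl in Place of Phenylsulfonyl: Compound 4

This account rests on a few compounds, and the source may have more. Where it says the series, first, only, none or still open, it means among the compounds named here.

Measured in a functional assay on SK-MEL-2 cells (Homo sapiens) for inhibition, read by sulforhodamine B assay, with a stated time of 48 h; on this read-out lower numbers stand for stronger inhibition of growth and higher numbers for weaker inhibition of growth:
compound 1, `COc1ccc(-c2[nH]c3ccccc3c2/C=C(\C#N)S(=O)(=O)c2ccccc2)cc1`, gives 18100 nM
compound 2, `CC(=O)/C(=C\c1c(-c2ccccc2)[nH]c2ccccc12)S(=O)(=O)c1ccccc1`, gives 1400 nM
compound 3, `N#C/C(=C\c1c(-c2ccccc2)[nH]c2ccccc12)S(=O)(=O)c1ccccc1`, gives 12700 nM

Compound 3 stands second highest of the three numbers in this assay; its nearest neighbour is compound 1, with a 1.4-fold lower number from compound 1 to compound 3 (0.15 log units; within the scatter), and its furthest is compound 2, with a 9.1-fold higher number from compound 2 to compound 3 (0.96 log units; beyond the scatter).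

Compound 4, `N#C/C(=C\c1c(-c2ccccc2)[nH]c2ccccc12)C(=O)c1ccccc1`, differs from compound 3 by benzoyl in place of phenylsulfonyl on a double-bonded chain carbon bound to a double-bonded chain carbon and a triple-bonded carbon. Within the data shown here, none of the measured steps makes this same exchange. Among the measured compounds shown here, the only step that touches the same double bond, from compound 2 to compound 3, swapped the group on the other chain carbon, and there a carbonyl-bearing compound gave the lower number. Taking that as a loose hint only, a small lowering of the number for compound 4 is expected, a 2.1-fold lower number from compound 3 to compound 4 (0.33 log units; beyond the scatter), with wide uncertainty. The estimate for compound 4 in this assay is 6000 nM, within a range from 1500 nM to 25000 nM.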

Compound 4, concentration for 50% growth inhibition: 35200 nM
Beside the measured number, compound 4's estimate is 5.9-fold (0.77 log units) below it; the measured number lies above the stated range.
By their numbers in this assay, from the lowest: compound 2; then compounds 3, 1 and 4 (each within the scatter of the next, the first and the last beyond it).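

In this assay, the only step shown that replaces phenylsulfonyl goes upward, a 2.8-fold higher number from compound 3 to compound 4 (0.44 log units; beyond the scatter), so on this double-bonded chain carbon benzoyl is not an equal stand-in for phenylsulfonyl, though the change is modest. The earlier step of a 9.1-fold higher number from compound 2 to compound 3 (0.96 log units; beyond the scatter) had linked acetyl with the lower number, whereas here benzoyl carries the higher one, so among these compounds a carbonyl group does not go with a lower number in both steps, and compound 4 stands against any such pattern. Nothing given here accounts for this step.

The compounds shown leave open how an amine or a carboxylic acid in place of phenylsulfonyl would read at this place. They also leave open whether benzoyl would give a step of similar size and direction with acetyl in place of cyano.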